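A few compounds are considered here, and "the series" means these few. Any claim that something is new, unique, unknown or untested is made for them only; others in the source may bear on it.

In a functional assay on MCF7 cells (Homo sapiens) (on this read-out higher numbers stand for weaker inhibition of growth and lower numbers for stronger inhibition of growth), three compounds that share one core and differ only in the ring group on a double-bonded chain carbon have been measured. Compound 1 `O=S(=O)(/C=C/c1ccc(Br)cc1)Cc1ccc(Nc2ncnc3ccccc23)cc1` gives 91000 nM, compound 2 `O=S(=O)(/C=C/c1ccc(F)cc1Cl)Cc1ccc(Nc2ncnc3ccccc23)cc1` gives 21000 nM, and compound 3 `O=S(=O)(/C=C/c1ccc(C(F)(F)F)cc1F)Cc1ccc(Nc2ncnc3ccccc23)cc1` gives 100000 nM. Compound 3 therefore sits at the weak end of these numbers, with a 1.1-fold higher number from compound 1 to compound 3 (0.04 log units; within the scatter) and a 4.8-fold higher number from compound 2 to compound 3 (0.68 log units; beyond the scatter).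

The unmeasured compound 4 `O=S(=O)(/C=C/c1ccc(O)cc1)Cc1ccc(Nc2ncnc3ccccc23)cc1` keeps the core and changes that same ring group: 4-hydroxyphenyl in place of 2-fluoro-4-(trifluoromethyl)phenyl on a double-bonded chain carbon bound to a double-bonded chain carbon. For the measured compounds named here, the steps that bear on this change are the other swaps at this place. One of them, a 4.3-fold lower number from compound 1 to compound 2 (0.64 log units; beyond the scatter), is modest, and the other, a 1.1-fold higher number from compound 1 to compound 3 (0.04 log units; within the scatter), does not exceed the scatter. Going by the values given here, no measured compound carries the 4-hydroxyphenyl group, so the data offer only an indirect guide. Swaps at this place have so far produced either no real change or a modest one, and the only route away from the weak end is the drop seen in compound 2 at 21000 nM. A modest move to a lower number is therefore expected in this assay. The estimated change is a 2.5-fold lower number from compound 3 to compound 4 (0.40 log units; beyond the scatter). The expected value for compound 4 is 40000 nM, with an estimated range of 12000 nM to 120000 nM.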

Compound 4, concentration for 50% growth inhibition: 100000 nM
Estimate against measurement, compound 4: 2.5-fold (0.40 log units) below; the measured number falls inside the stated range.
By their numbers in this assay, from the lowest: compound 2; then compounds 1, 3 and 4 (each within the scatter of the next).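

In this assay, 4-hydroxyphenyl in place of 2-fluoro-4-(trifluoromethyl)phenyl gives no change at the digits printed from compound 3 to compound 4 (within the scatter), and hydroxy in place of bromo on an aromatic carbon gives a 1.1-fold higher number from compound 1 to compound 4 (0.04 log units; within the scatter), so a smaller group carrying a hydrogen-bond donor and acceptor reads level with a larger group that has neither. The one clear separation at this place remains 2-chloro-4-fluorophenyl, with a 4.8-fold higher number from compound 2 to compound 4 (0.68 log units; beyond the scatter), and together with its earlier steps this makes compound 2 the strongest growth inhibitor of the four, while the other three cannot be ordered. Nothing available offers an explanation for this pattern.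

The compounds shown leave open whether the advantage of compound 2 lies in the chloro group, the fluoro group or the two together, which 2-chlorophenyl and 4-fluorophenyl analogues could help separate. Also open, going by these compounds, is how an amine or a carboxylic acid on the ring at this place would read, and whether any such group could move the number well beyond that of compound 2.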